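Chloro for bromo where every measured value is a limit

The compounds below may be only part of what the source reports. "The series", "measured", "known", "first", "only" and "open" are said of these compounds alone.

The measured compounds and their values in this study:
compound 1 `C=C1C[C@]23C[C@@]1(O)CC[C@H]2c1ccc(OS(=O)(=O)c2ccc(C)cc2)c(C)c1[C@@H]3Cn1cc(-c2ccc(Br)cc2)nn1`: > 20000 nM
compound 2 `C=C1C[C@]23C[C@@]1(O)CC[C@H]2c1ccc(O)c(C)c1[C@@H]3Cn1cc(-c2ccc(Br)cc2)nn1`: > 20000 nM
compound 3 `COc1ccc(-c2cn(C[C@H]3c4c(ccc(OS(=O)(=O)c5ccc(C)cc5)c4C)[C@@H]4CC[C@@]5(C)C[C@]43CC5=O)nn2)cc1`: > 20000 nM

In a functional assay on A549 cells (Homo sapiens) for cytotoxicity, read by MTT assay, with a stated time of 4 days (on this read-out higher numbers stand for weaker inhibition and lower numbers for stronger inhibition), compound 2 gives > 20000 nM, which is a limit of the assay and not a number. Compound 1 likewise gives > 20000 nM in this assay, again a limit. Compound 3 also stands at a limit, > 20000 nM. All that can be said of the set is summed up by the limit of > 20000 nM in this assay, at which 3 of the 3 values shown sit. Going by the values given here, the one pair that differs in a single place, compound 1 and compound 2, yields a step that the two limits leave unreadable from compound 1 to compound 2, so no readable step exists among the measured compounds.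

Compound 4 `C=C1C[C@]23C[C@@]1(O)CC[C@H]2c1ccc(O)c(C)c1[C@@H]3Cn1cc(-c2ccc(Cl)cc2)nn1` has not been measured. It differs from compound 2 by chloro in place of bromo on an aromatic carbon. Among the compounds with values here, no measured step bears on this change: the only step on record is unreadable, and every value shown is a limit. With nothing pointing away from the limit, compound 4 is expected to stay there, the expected step that the limit leaves unreadable from compound 2 to compound 4 being none beyond the scatter. The estimate for compound 4 in this assay is 30000 nM, with a range from 10000 nM to 100000 nM, and most likely only a limit will be reported.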

Compound 4, half-maximal inhibitory concentration: > 20000 nM
Compound 4 ended at the assay's limit; the forecaster's own chance of this, stated with the estimate: 85%; the middle value is on the limit's open side.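

In this assay compound 4 gives > 20000 nM, which is a limit of the assay and not a number. Compound 2 gives > 20000 nM, also a limit, so no step can be read between compound 2 and compound 4. The compounds shown leave open what change to the shared core, if any, would give a readable value in this assay.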